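Sulfonylurea series: aromatic amide in place of trifluoroacetamide

The source may report more compounds than this note shows. Statements on the series, on what has been measured and on what is new or still open speak of the compounds shown alone.

Three compounds of the series have numbers in a functional assay on the whole organism (blood) with Rattus norvegicus as the target, with stated times of 24 h and 1 h, at a dose of 5 mg/kg by the intraperitoneal route; a higher number here means a stronger effect of the compound at the dose given, a lower number a weaker effect. Compound 1 `O=C(NC1CCCCC1)NS(=O)(=O)N1CCC(CCNC(=O)C(F)(F)F)CC1` gives 13%, compound 2 `O=C(NC[C@@H]1C[C@@H]2C=C[C@@H]1C2)NS(=O)(=O)N1CCC(CCNC(=O)C(F)(F)F)CC1` gives 22%, and compound 3 `CCCNC(=O)NS(=O)(=O)N1CCC(CCNC(=O)c2cscn2)CC1` gives 10%. Compound 2 sits at the top of the three numbers, though its distance to compound 1 lies within the scatter and only its distance to compound 3 lies beyond it. Within the data shown here, the one single-site step available, a number 9 percentage points higher from compound 1 to compound 2 (within the scatter), concerns the group on the amide-type nitrogen and not the carbonyl end of the chain.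

Compound 4 `O=C(NC[C@@H]1C[C@@H]2C=C[C@@H]1C2)NS(=O)(=O)N1CCC(CCNC(=O)c2cc(Cl)cc3cccnc23)CC1` is not yet measured in this assay. It differs from compound 2 as follows: 6-chloroquinolin-8-yl in place of trifluoromethyl on a carbonyl carbon. Among the measured compounds shown here, no measured step touches this carbonyl carbon in isolation; compound 3 carries an aromatic ring there but differs from compound 2 in a second place as well, so its value only shows that such a compound can sit lower in this assay. With nothing that bears directly on the change, no step beyond the scatter is expected, and compound 4 is estimated at 20% (range 5% to 40%), which would mean a step of a number 2 percentage points lower from compound 2 to compound 4 (within the scatter).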

Compound 4, a percentage reported as activity, at one dose (the size of the read-out at that dose, not a potency): 35%
The estimate for compound 4 lay 15 percentage points below the measured number, and the stated range covers the measured number.
By their numbers in this assay, from the lowest: compounds 3, 1 and 2 (each within the scatter of the next, the first and the last beyond it); then compound 4.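

Among these compounds, with the group on the amide-type nitrogen held constant, 6-chloroquinolin-8-yl in place of trifluoromethyl on a carbonyl carbon gives a number 13 percentage points higher from compound 2 to compound 4 (beyond the scatter) in this assay, the first single-site reading at this position. The position therefore accepts a group with two six-membered aromatic rings in place of one with no ring without loss of the read-out, which compound 3, differing in a second place as well, could not show. Among the compounds shown here, a change here also moves the number beyond the scatter, whereas the one earlier single-site step, on the amide-type nitrogen, stayed within it, though nothing at hand indicates what underlies the step.

As far as these compounds go, it remains open whether the step depends on the chlorine or on the ring nitrogen, which quinolin-8-yl or a plain phenyl group on the same carbonyl carbon would separate. From the compounds shown here alone, it is also open whether the step holds with the cyclohexyl group of compound 1 on the amide-type nitrogen, and how it would look at doses other than this single one.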